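Flipping the second ring stereocentre in a dimeric exchanger blocker

This account rests on a few compounds, and the source may have more. Where it says the series, first, only, none or still open, it means among the compounds named here.

Compound 2 `CN1Cc2c(Cl)cc(Cl)cc2[C@@H](c2cccc(S(=O)(=O)NCCOCCOCCOCCNC(O)C(O)C(=O)NCCOCCOCCOCCNS(=O)(=O)c3cccc([C@@H]4CN(C)Cc5c(Cl)cc(Cl)cc54)c3)c2)C1` is the weaker of two measured molecules: in an assay on cells (Kidney epithelial cell, kidney) for inhibition of sodium/hydrogen exchanger 3 (Homo sapiens), read by fluorescence, in the presence of a further agent that is not named here (on this read-out higher numbers stand for weaker inhibition and lower numbers for stronger inhibition), compound 2 gives 200 nM, whereas compound 1 `CN1Cc2c(Cl)cc(Cl)cc2[C@H](c2cccc(S(=O)(=O)NCCOCCOCCOCCNC(=O)C(O)C(O)NCCOCCOCCOCCNS(=O)(=O)c3cccc([C@@H]4CN(C)Cc5c(Cl)cc(Cl)cc54)c3)c2)C1` gives 1.26 nM, and the step of a 160-fold higher number from compound 1 to compound 2 (2.20 log units; beyond the scatter) is large. Compound 3 `CN1Cc2c(Cl)cc(Cl)cc2[C@@H](c2cccc(S(=O)(=O)NCCOCCOCCOCCNC(=O)C(O)C(O)NCCOCCOCCOCCNS(=O)(=O)c3cccc([C@H]4CN(C)Cc5c(Cl)cc(Cl)cc54)c3)c2)C1` is the next molecule to be tested. The change is the two compounds have the same atoms and bonds; at least one stereo element is drawn with a configuration in one of them and without one in the other: 1 of 4 stereo elements differ; a stereocentre at a saturated ring carbon is drawn S in compound 2 and R in compound 3, so it alters how one half of the molecule is arranged in space, not which atoms it contains. Going by the values given here, the only measured step that bears on this kind of change is a 160-fold higher number from compound 1 to compound 2 (2.20 log units; beyond the scatter), which came from flipping the other ring stereocentre and raised the number sharply; that drop in potency is tied to the fact that one of compounds 1 and 2 is drawn with a defined configuration and the other without, at the place where they differ. A further flip is therefore expected to push the number up again rather than down, though by an uncertain amount. Compound 3 is estimated at 1000 nM, between 200 nM and 6000 nM, a step of a 5.0-fold higher number from compound 2 to compound 3 (0.70 log units; beyond the scatter).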

Compound 3, half-maximal inhibitory concentration: > 31600 nM
Compound 3 ended at the assay's limit; the forecaster's own chance of this, stated with the estimate: 20%; at least 31-fold (1.49 log units) between middle value and limit.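

In this assay the second stereocentre at a saturated ring carbon matters too, not only the first: changing it from S to R gives an at least 150-fold higher number from compound 2 to compound 3 (2.19 log units; beyond the scatter), so a compound already weakened by one flip loses still more with the other. With both centres changed, the full distance is an at least 25000-fold higher number from compound 1 to compound 3 (4.39 log units; beyond the scatter), which means that among these three compounds each flip from S to R comes with a large loss and the dimer tolerates neither flip. Compound 3 stands at a limit of the assay, not at a number, so both steps are only lower bounds: the limit of > 31600 nM in this assay, at which 1 of the 3 values shown sits.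

As far as these compounds go, how far compound 3 truly lies beyond that limit remains open. So does whether a longer chain joining the two halves would change what each flip costs.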